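The source may hold more compounds than are shown below. What is called first, only, known or untested is meant among the compounds shown, and "the series" means these compounds.

In an ADME assay on MRC5 cells (Homo sapiens) for cytotoxicity, read by fluorescence and resazurin assay, with a stated time of 3 days (a lower number here means a stronger inhibitor, a higher number a weaker inhibitor), the measured compounds read as follows:
- compound 1 (`Cc1cccc(Oc2cccc(CN3CCC(n4cc(C)c(=O)[nH]c4=O)CC3)c2)c1`) gives > 64000 nM (a limit of the assay, not a number)
- compound 2 (`COc1ccc(Oc2cccc(CN3CCC(n4cc(C)c(=O)[nH]c4=O)CC3)c2)cc1`) gives 28000 nM
- compound 3 (`COc1cccc(Oc2cccc(CN3CCC(n4cc(C)c(=O)[nH]c4=O)CC3)c2)c1`) gives 25300 nM

Compound 3 stands level with compound 2, the gap being a 1.1-fold lower number from compound 2 to compound 3 (0.04 log units; within the scatter) and so no real difference. Next comes compound 4 (`Cc1cn(C2CCN(Cc3cccc(Oc4cccc(Cl)c4)c3)CC2)c(=O)[nH]c1=O`), with chloro in place of methoxy on an aromatic carbon, meta to a large group (chloro in place of methoxy on an aromatic carbon). For the measured compounds named here, no measured step makes this exact swap. The closest is an at least 2.5-fold lower number from compound 1 to compound 3 (0.40 log units; beyond the scatter) for methoxy in place of methyl, and an at least 2.2-fold lower number from compound 1 to compound 2 (0.35 log units; beyond the scatter) points the same way. On these data alone, both start from a limit, so their full size is unknown. With the methoxy gone from compound 4, a small move back towards a higher number seems likely, since compound 1 without it gives the limit. As far as these compounds go, the expected change is a 1.5-fold higher number from compound 3 to compound 4 (0.18 log units; within the scatter) in this assay, though chloro itself is untested here. For compound 4 the estimate is 38000 nM, with an expected range from 15000 nM to 64000 nM.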

Compound 4, half-maximal inhibitory concentration: 21000 nM
Compound 4: middle estimate off by 1.8-fold (0.26 log units), on the high side; the measured number falls inside the stated range.
By their numbers in this assay, from the lowest: compounds 4, 3 and 2 (each within the scatter of the next). At a limit, above all of these: compound 1.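

In this assay, chloro serves this position as well as methoxy does, a 1.2-fold lower number from compound 3 to compound 4 (0.08 log units; within the scatter), so a number in this range does not depend on the methoxy group. The same holds against the 4-methoxyphenyl group, a 1.3-fold lower number from compound 2 to compound 4 (0.12 log units; within the scatter), which leaves three compounds level despite their different groups. Only the methyl group stands apart, an at least 3.0-fold lower number from compound 1 to compound 4 (0.48 log units; beyond the scatter), and this size is only a minimum, because compound 1 gives a limit and not a number: the limit of > 64000 nM in this assay, at which 1 of the 4 values shown sits.

On these data alone, what remains open is how far the level result extends beyond chloro and methoxy at this position. A fluoro group, a nitrile, an amine or a carboxylic acid in the same place would show whether other groups also stay level or move beyond the scatter, as methyl does.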